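The source may hold more compounds than are shown below. What is called first, only, known or untested is meant among the compounds shown, and "the series" means these compounds.

The study brings together three measured compounds and one that still awaits measurement in an assay on HEK-293T cells for inhibition of phospholipase A and acyltransferase 3 (Homo sapiens), with stated times of 30 min and 20 min; on this read-out higher numbers stand for weaker inhibition and lower numbers for stronger inhibition. Compound 1 `O=C(NCc1ccccc1)C(F)(F)C(O)CCc1ccccc1` gives in this assay > 10000 nM, which is a limit of the assay and not a number. Compound 2 `O=C(CCc1ccccc1)CC(=O)NCc1ccccc1` gives in this assay > 10000 nM, again a limit rather than a number. Compound 3 `O=C(CCc1ccc(Cl)cc1)C(=O)N1CCCCC1` carries a piperidin-1-yl group on a carbonyl carbon, and in this assay compound 3 gives > 10000 nM, likewise a limit. Compound 3 thus stands where every measured value stands, at the limit of > 10000 nM in this assay, at which 3 of the 3 values shown sit; none of the three compounds can be set above or below another. Among the compounds with values here, no two measured compounds differ in a single place, so no measured step is available to show how any change moves the read-out.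

Compound 4 `CN(C)C(=O)C(=O)CCc1ccc(Cl)cc1` differs from compound 3 by dimethylamino in place of piperidin-1-yl on a carbonyl carbon. With all measured values resting at the limit, nothing suggests a direction for this change, and compound 4 is expected to remain at the limit, so that the step from compound 3 to compound 4 is estimated as a step that the limit leaves unreadable from compound 3 to compound 4. Compound 4 is expected to give about 15000 nM in this assay, within a range from 5000 nM to 50000 nM.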

Compound 4, half-maximal inhibitory concentration: > 10000 nM
Compound 4 ended at the assay's limit; the forecaster's own chance of this, stated with the estimate: 85%; the middle value is on the limit's open side.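

Within the data shown here, compound 3 and compound 4 both rest at a limit of this assay, so no step between them can be read for dimethylamino in place of piperidin-1-yl. All the compounds shown share one limit: the limit of > 10000 nM in this assay, at which 4 of the 4 values shown sit.

The compounds shown leave open how they rank against one another and which change, if any, would bring a measurable value in this assay.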